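The compounds below may be only part of what the source reports. "The series", "measured", "known", "first", "only" and "open" are said of these compounds alone.

Measured compounds:
compound 1 `O=C(O)CSC(CC(=O)c1ccccc1)C(=O)O` — 15000 nM
compound 2 `CCc1ccc(C(=O)CC(SCC(=O)O)C(=O)O)cc1` — 4790 nM

Among the compounds with values here, in a functional assay on HeLa cells (Homo sapiens) for inhibition (a higher number here means a weaker inhibitor, a lower number a stronger inhibitor), compound 2 gives 4790 nM, the lowest of the two numbers so far. Compound 1 gives 15000 nM in this assay, the step of a 3.1-fold lower number from compound 1 to compound 2 (0.50 log units; beyond the scatter) being the only measured one in the series.

Compound 3 `CC(C)c1ccc(C(=O)CC(SCC(=O)O)C(=O)O)cc1` differs from compound 2 by methyl in place of hydrogen on a saturated chain carbon bound to an aromatic carbon and a saturated chain carbon. Within the data shown here, the one measured step bears on this change only loosely: it grew the same side chain from nothing to ethyl, whereas here the chain is extended further to isopropyl. Among the measured compounds shown here, a continuation of that trend is plausible but unsupported, as the series holds no second step to tell whether further growth keeps lowering the number. The expected step for compound 3 in this assay is therefore small and downward, a 1.4-fold lower number from compound 2 to compound 3 (0.14 log units; within the scatter), close to the scatter. Compound 3 is expected at 3500 nM, within 1500 nM to 9000 nM.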

Compound 3, half-maximal inhibitory concentration: 3330 nM
The estimate for compound 3 lay 1.1-fold (0.02 log units) above the measured number; measured number inside the range.
By their numbers in this assay, from the lowest: compounds 3 and 2 (each within the scatter of the next); then compound 1.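

Going from ethyl to isopropyl gives a 1.4-fold lower number from compound 2 to compound 3 (0.16 log units; within the scatter) in this assay, so adding methyl on this saturated chain carbon does not separate the two groups, and the series gives no sign of further movement from this change. Measured directly against the hydrogen of compound 1, isopropyl gives a 4.5-fold lower number from compound 1 to compound 3 (0.65 log units; beyond the scatter), which places isopropyl with ethyl as a replacement for that hydrogen, with a step beyond the scatter for both groups. No available evidence accounts for either step.

On these data alone, whether a longer chain such as n-butyl, or tert-butyl, would leave the number in the same range remains open, as does the outcome with an amine or a methoxy group in that place. All three compounds keep both carboxylic acids, so the effect of replacing either with an amide or a methyl ester is also unknown.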